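Demethylation of a phenol ether in a pyrazole urea pair

A few compounds are considered here, and "the series" means these few. Any claim that something is new, unique, unknown or untested is made for them only; others in the source may bear on it.

Of the compounds shown here, two have numbers so far. Compound 1 `O=C(Nc1cccc(-n2cc(-c3ccncc3)c(-c3ccc(Cl)c(O)c3)n2)c1)Nc1cccc(C(F)(F)F)c1` carries a hydroxy group on one of its aryl rings and a trifluoromethylphenyl urea; in a functional assay on COLO 205 cells (Homo sapiens) for inhibition, read by sulforhodamine B assay, with a stated time of 48 h (on this read-out higher numbers stand for weaker inhibition of growth and lower numbers for stronger inhibition of growth), compound 1 gives 7900 nM. Compound 2 `COc1cc(-c2nn(-c3cccc(NC(=O)Nc4ccc(Cl)c(C(F)(F)F)c4)c3)cc2-c2ccncc2)ccc1Cl` carries instead a methoxy group and a chlorotrifluoromethylphenyl urea; in this assay compound 2 gives 711 nM. Compound 2 holds the lower of the two numbers, and the gap to compound 1 lies beyond the usual scatter. The two compounds differ at two sites, and the pair does not show which change carries the difference.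

Compound 3 `O=C(Nc1cccc(-n2cc(-c3ccncc3)c(-c3ccc(Cl)c(O)c3)n2)c1)Nc1ccc(Cl)c(C(F)(F)F)c1` keeps the urea of compound 2 and differs from it in one place: hydrogen in place of methyl on an oxygen on an aromatic ring. For the measured compounds named here, no measured pair isolates this change, so the expectation rests on compound 1, which carries the hydroxy group and in this assay gave 7900 nM. A moderate shift toward weaker inhibition of growth is expected, the step from compound 2 to compound 3 being estimated at a 2.5-fold higher number from compound 2 to compound 3 (0.40 log units; beyond the scatter). For compound 3 the value in this assay is estimated at 1800 nM, within 500 nM to 6000 nM.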

Compound 3, concentration for 50% growth inhibition: 2390 nM
The estimate for compound 3 lay 1.3-fold (0.12 log units) below the measured number, within the range that was stated.
By their numbers in this assay, from the lowest: compound 2; then compound 3; then compound 1.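

In this assay the two-site difference can now be read one site at a time. Methoxy to hydroxy on the 4-chloro-3-methoxyphenyl ring alone gives a 3.4-fold higher number from compound 2 to compound 3 (0.53 log units; beyond the scatter) on the same urea, and chloro in place of hydrogen on an aromatic carbon of the urea's aryl ring gives a 3.3-fold lower number from compound 1 to compound 3 (0.52 log units; beyond the scatter) with the hydroxy group held constant. Both steps lie beyond the scatter, so neither change alone accounts for the gap between the first two compounds, and the methyl on the oxygen and the added chloro each go with stronger inhibition of growth; no evidence on the reason for either step is available.

Going by these compounds, each step is read in one background only, so it remains open whether methoxy to hydroxy has the same size on the urea lacking the chloro. On these data alone, how an ethoxy group, a longer chain on the oxygen or an amine in place of the hydroxy group would read in this assay also remains open.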